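The source may report more compounds than this note shows. Statements on the series, on what has been measured and on what is new or still open speak of the compounds shown alone.

Working notes on the series in a functional assay on cells (Cancer cell lines, Homo sapiens) for inhibition; a higher number here means a weaker inhibitor of growth, a lower number a stronger inhibitor of growth. Compound 1 `Cc1cn2c(/C=N/NC(=N)N)c(-c3ccsc3)nc2s1` gives 7590 nM, compound 2 `N=C(N)N/N=C/c1c(-c2ccsc2)nc2sccn12` gives 14800 nM and compound 3 `N=C(N)N/N=C/c1c(-c2ccsc2)nc2n1CCS2` gives 17400 nM. Compound 3 thus lies within the scatter of compound 2 and beyond it from compound 1, on the higher side. Compound 4 `N=C(N)N/N=C/c1c(-c2cccs2)nc2n1CCS2` carries thiophen-2-yl in place of thiophen-3-yl on an aromatic carbon. Among the measured compounds shown here, the only measured step, a 1.9-fold higher number from compound 1 to compound 2 (0.29 log units; within the scatter), is hydrogen in place of methyl and leaves the thiophene untouched, so no measured step tests this change directly. For the measured compounds named here, with only that small step as a guide, no shift beyond the scatter is expected. The expected step is a 1.2-fold lower number from compound 3 to compound 4 (0.06 log units; within the scatter). For compound 4 the estimate is 15000 nM, with an expected range of 6500 nM to 33000 nM.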

Compound 4, concentration for 50% growth inhibition: 19500 nM
For compound 4 the middle estimate is 1.3-fold (0.11 log units) below the measured one; the measured number falls inside the stated range.
By their numbers in this assay, from the lowest: compounds 1, 2, 3 and 4 (each within the scatter of the next, the first and the last beyond it).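

In this assay, thiophen-2-yl in place of thiophen-3-yl on this aromatic carbon gives a 1.1-fold higher number from compound 3 to compound 4 (0.05 log units; within the scatter), the first direct test of the group at this position. In this pair on the shared core, the point of attachment of the thiophene does not separate compound 3 from compound 4. Nothing available bears on the reason for this result.

Only these two thiophene isomers are shown at this position, so it remains open whether a phenyl ring, a pyridine or an amine there would separate from them.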